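This account rests on a few compounds, and the source may have more. Where it says the series, first, only, none or still open, it means among the compounds named here.

The study covers four compounds that share one core. Compound 1 `COc1ccc(-n2c(C)nc3c(N4CC[C@@H](NC(C)=O)C4)nc(C)nc32)cc1OC` was tested in an ADME assay on microsomes from liver (Homo sapiens) for metabolic stability, read by LC-MS, with NADPH named in the record, with a stated time of 60 min, tested at 1 uM, in the absence of a further agent (on this read-out lower numbers stand for a less stable compound and higher numbers for a more stable compound), where compound 1 gives > 95%, a limit of the assay. In this assay compound 2 `COc1ccc(-c2c(C)nc3c(N4CC[C@@H](NS(C)(=O)=O)C4)cc(C)nn23)cc1OC` gives > 95%, again a limit. Compound 3 `COc1ccc(-c2c(C)nc3c(N4CC[C@@H](NS(=O)(=O)c5ccc(C(C)=O)cc5)C4)cc(C)nn23)cc1OC` gives > 95% in this assay, also a limit. The measured step that the two limits leave unreadable from compound 2 to compound 3 therefore stays unreadable, because of the limit of > 95% in this assay, at which 3 of the 3 values shown sit. Compound 4 `COc1ccc(-c2c(C)nc3c(N4CC[C@@H](N=[N+]=[N-])C4)cc(C)nn23)cc1OC` differs from compound 2 in one place: azido in place of methanesulfonamido on a saturated ring carbon. Within the data shown here, no measured step bears on this change, and compound 2 itself stands only at a limit. Compound 4 is expected to remain at that limit, an estimated step of a number no higher from compound 2 to compound 4 (the limit leaves the size open). Compound 4 is therefore estimated at 95%, with a range from 85% to 99%.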

Compound 4, percent of the compound remaining: > 95%
Compound 4: a limit, no number; the forecaster's own chance of this, stated with the estimate: 70%; the middle value sits exactly at the limit.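

In this assay no new step can be read between compound 2 and compound 4, because both stand at a limit: the limit of > 95% in this assay, at which 4 of the 4 values shown sit.

The compounds shown leave open whether azido in place of methanesulfonamido changes the percent of compound remaining at all.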